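Working notes: from compound 3 to compound 4

The source may hold more compounds than are shown below. What is called first, only, known or untested is meant among the compounds shown, and "the series" means these compounds.

Values in an ADME assay on L02 cells (Homo sapiens) for cytotoxicity, read by MTT assay (on this read-out higher numbers stand for weaker inhibition and lower numbers for stronger inhibition), each one a limit of the assay:
- compound 1 `COc1ccc(/C=C/C(=O)c2ccc(OC)c3c2OC(C)(C)C=C3)cc1OCCO` gives > 10000 nM as a limit
- compound 2 `C=CC(=O)Oc1cc(/C=C/C(=O)c2ccc(OC)c3c2OC(C)(C)C=C3)ccc1OC` gives > 10000 nM as a limit
- compound 3 `COc1ccc(/C=C/C(=O)c2ccc(OC)c3c2OC(C)(C)C=C3)cc1OC(=O)CCl` gives > 10000 nM as a limit

Compound 3 has no number in this assay and sits at the same limit as the other two compounds (the limit of > 10000 nM in this assay, at which 3 of the 3 values shown sit).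

The change to compound 4 (`COc1ccc(/C=C/C(=O)c2ccc(OC)c3c2OC(C)(C)C=C3)cc1OC(=O)c1ccc(Br)cc1`) puts 4-bromophenyl in place of chloromethyl on a carbonyl carbon.

The closest measured change falls on that same carbonyl carbon, but it is a step that the two limits leave unreadable from compound 2 to compound 3 and so gives no size to carry over. Both a step that the two limits leave unreadable from compound 1 to compound 2 and a step that the two limits leave unreadable from compound 1 to compound 3 leave the same gap. Going by the values given here, no measured step therefore has a readable size or direction.

With nothing readable from compound 2 or compound 3 in a step that the two limits leave unreadable from compound 2 to compound 3, no step beyond the scatter is expected in this assay, and a further limit is the likeliest report. The expected step is a step that the limit leaves unreadable from compound 3 to compound 4 and it remains an estimate with no firm direction. Compound 4 is estimated at 12000 nM (expected range 5000 nM to 30000 nM) if a number is reported at all.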

Compound 4, half-maximal inhibitory concentration: 8400 nM
The estimate for compound 4 lay 1.4-fold (0.15 log units) above the measured number; low and high end bracket the measured number.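

In this assay, going by these compounds alone, the carbonyl carbon gives the first actual number of the series: with 4-bromophenyl in place of chloromethyl, the result is an at least 1.1-fold lower number from compound 3 to compound 4 (0.07 log units; that floor lies within the scatter). The reading is the same with 4-bromophenyl in place of vinyl on that carbon, an at least 1.1-fold lower number from compound 2 to compound 4 (0.07 log units; that floor lies within the scatter), and with (4-bromophenyl)carbonyl in place of 2-hydroxyethyl on the oxygen, an at least 1.1-fold lower number from compound 1 to compound 4 (0.07 log units; that floor lies within the scatter). This position can therefore carry a group that yields a number, but each of these steps is only a floor within the scatter, so no real shift is established, the steps among compound 1, compound 2 and compound 3 cannot be read, and most of the series stays at one value: the limit of > 10000 nM in this assay, at which 3 of the 4 values shown sit.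

On these data alone, it remains open whether a plain phenyl, a 4-chlorophenyl or a longer alkyl chain on the same carbonyl carbon would also give a number in this assay, which would separate the part played by the ring from that of the bromine. Also open, as far as these compounds go, is how an amine or a carboxylic acid on the phenyl ring at this carbonyl carbon would read.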